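The compounds below may be only part of what the source reports. "The series", "measured", "known", "first", "only" and "open" are said of these compounds alone.

Working notes on the series. Within the data shown here, in a functional assay on DU-145 cells (Homo sapiens) for antiproliferative activity, read by sulforhodamine B assay, with a stated time of 72 h (on this read-out lower numbers stand for stronger inhibition and higher numbers for weaker inhibition), compound 1 (`O=S(=O)(Nc1nccs1)c1ccc(Nc2nncc3ccccc23)cc1`) reads 24 nM and compound 2 (`Cc1cc(NS(=O)(=O)c2ccc(Nc3nncc4ccccc34)cc2)no1`) reads 35 nM in this read-out, so compound 2 stands within the scatter of the only other measured compound. Compound 3 (`NS(=O)(=O)c1ccc(Nc2nncc3ccccc23)cc1`) has not yet been measured. The change from compound 2 to compound 3 is hydrogen in place of 5-methyl-1,2-oxazol-3-yl on a sulfonamide nitrogen and amounts to hydrogen in place of 5-methyl-1,2-oxazol-3-yl on a sulfonamide nitrogen.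

Among the measured compounds shown here, one measured step bears on this change: a 1.5-fold higher number from compound 1 to compound 2 (0.16 log units; within the scatter) stays within the scatter. That step exchanges one group on the sulfonamide nitrogen for another, so it gives only indirect guidance. For the measured compounds named here, no measured compound carries hydrogen at this place, and the loss of the group has not been tested. A step beyond the scatter is therefore possible in this assay and a higher number is tentatively expected, although the direction is uncertain. The expected move is a 2.6-fold higher number from compound 2 to compound 3 (0.41 log units; beyond the scatter) on this limited evidence. For compound 3 the estimated value is 90 nM with an expected range of 20 nM to 400 nM as a working figure.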

Compound 3, half-maximal inhibitory concentration: 14 nM
The estimate for compound 3 lay 6.4-fold (0.81 log units) above the measured number; the whole stated range lies above it.
By their numbers in this assay, from the lowest: compounds 3, 1 and 2 (each within the scatter of the next, the first and the last beyond it).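

In this assay, replacing 5-methyl-1,2-oxazol-3-yl with hydrogen on the sulfonamide nitrogen gives (a 2.5-fold lower number from compound 2 to compound 3 (0.40 log units; beyond the scatter)), a modest step beyond the scatter, so this aromatic ring is not required for a low number at this position. Replacing 1,3-thiazol-2-yl with hydrogen at the same place gives (a 1.7-fold lower number from compound 1 to compound 3 (0.23 log units; within the scatter)), which stays within the scatter, so compound 1 and compound 3 cannot be ordered. Among these three compounds, the only separation beyond the scatter is therefore between compound 2 and compound 3, and the unsubstituted sulfonamide nitrogen of compound 3 is at least compatible with activity in the same range as compound 1.

As far as these compounds go, whether a small open-chain group such as methyl or acetyl, or a six-membered ring such as pyridin-2-yl, on this nitrogen would read with compound 3 or with compound 2 remains open. No measurement at hand accounts for the step from the ring-bearing compounds to the hydrogen compound.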